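Hydroxy to amino on a dimethylated isoquinoline-like core

The source may report more compounds than this note shows. Statements on the series, on what has been measured and on what is new or still open speak of the compounds shown alone.

Compound 1, `COc1ccc(-c2cc3ccccc3c(-c3cccc(O)c3)n2)cc1`, and compound 2, `COc1ccc(-c2cc3ccccc3c(-c3cccc(N)c3)n2)cc1`, share one core and differ in a single place: amino in place of hydroxy on an aromatic carbon. In an assay on isolated protein for inhibition of DNA topoisomerase 1 (Homo sapiens), with a stated time of 30 min, tested at 100 uM (on this read-out higher numbers stand for a stronger effect at the one concentration tested and lower numbers for a weaker effect), compound 1 gives 9.4%, and compound 2 gives 0%; the step of a number 9.4 percentage points lower from compound 1 to compound 2 (within the scatter) is within the scatter, so on this pair the change leaves the read-out essentially unaltered. Compound 3, `COc1ccc(-c2cc3cc(C)ccc3c(-c3cccc(O)c3)n2)c(C)c1`, is built on a different core; how its core differs from that of compound 1 is not broken down here. In this assay compound 3 gives 73.4%, the highest of the three numbers.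

Compound 4, `COc1ccc(-c2cc3cc(C)ccc3c(-c3cccc(N)c3)n2)c(C)c1`, is not yet measured. It is made from compound 3 by amino in place of hydroxy on an aromatic carbon, the same change as that from compound 1 to compound 2, at a place described in the same words. Because the earlier step of a number 9.4 percentage points lower from compound 1 to compound 2 (within the scatter) was within the scatter, the expected step for the new pair is also small, a number 15.4 percentage points lower from compound 3 to compound 4 (beyond the scatter), though the higher starting number of compound 3 leaves room for a larger fall. The estimated inhibition for compound 4 is therefore 58%, expected between 28% and 80%.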

Compound 4, a percentage reported as inhibition, at one concentration (the size of the read-out at that concentration, not a potency): 79.7%
Estimate against measurement, compound 4: 21.7 percentage points below; the range from low to high includes it.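

In this assay, among the compounds shown here, changing 3-hydroxyphenyl to 3-aminophenyl on the core of compound 3 gives a number 6.3 percentage points higher from compound 3 to compound 4 (within the scatter), so on this core, as on the core of compound 1, the single step leaves the read-out essentially unaltered. Set side by side, however, the two steps run in opposite directions, and the gap between them is larger than the scatter allows, so the change does not carry over as exactly the same step from one core to the other: the same change on two cores in this assay, a number 9.4 percentage points lower (within the scatter) from compound 1 to compound 2 and a number 6.3 percentage points higher (within the scatter) from compound 3 to compound 4, 15.7 percentage points apart, beyond the scatter of two such steps This rests on just two pairs, each with a step that is small on its own, and it does not show which feature of the two cores accounts for the gap or how the change would behave on a third core.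

The compounds shown leave open how other groups would read out at this place on the ring, such as a methoxy group, a carboxylic acid or an amide. They also leave open whether the amino group would stay level with the hydroxy group on any further core.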